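The source may report more compounds than this note shows. Statements on the series, on what has been measured and on what is new or still open speak of the compounds shown alone.

Compound 1 `COc1cc(-c2cc(/C=C/C(=O)c3ccc(N)cc3)[nH]n2)cc(OC)c1OC` is the starting point. In a functional assay on NCI-H226 cells (Homo sapiens) for inhibition, read by sulforhodamine B assay, with a stated time of 48 h (a lower number here means that less compound is tolerated, a higher number that more compound is tolerated), compound 1 gives 7180 nM, the lowest of the two numbers available here. Compound 2 `COc1ccc(-c2cc(/C=C/C(=O)c3ccc(N)cc3)[nH]n2)cc1OC` differs from it only in one methoxy group and gives 76200 nM; that change is an 11-fold higher number from compound 1 to compound 2 (1.03 log units; beyond the scatter). Compound 3 `COc1ccc(-c2cc(/C=C/C(=O)c3cc(OC)c(OC)c(OC)c3)[nH]n2)cc1OC` carries a different ring on the carbonyl carbon and reaches only a limit of this assay, > 100000 nM, so no number is known for it. Compound 4 `COc1cc(-c2cc(/C=C/C(=O)c3ccc(F)c(F)c3)[nH]n2)cc(OC)c1OC` keeps everything of compound 1 except the ring on the carbonyl carbon: 3,4-difluorophenyl in place of 4-aminophenyl on a carbonyl carbon. For the measured compounds named here, no measured step concerns this part of the molecule; the only measured step concerns a methoxy group on an aromatic carbon. What compound 2 and compound 3 show together is that exchanging the 4-aminophenyl ring for another ring pushed the result to the limit. A moderate rise is therefore expected, a 3.5-fold higher number from compound 1 to compound 4 (0.54 log units; beyond the scatter), with wide uncertainty. Compound 4 is estimated at 25000 nM, between 6000 nM and 100000 nM.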

Compound 4, concentration lethal to 50% of the cells: 66000 nM
Compound 4: the middle estimate sits 2.6-fold (0.42 log units) below what was measured; low and high end bracket the measured number.
By their numbers in this assay, from the lowest: compound 1; then compounds 4 and 2 (each within the scatter of the next). At a limit, above all of these: compound 3.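

For the compounds shown here, this is the first measured step at the ring on the carbonyl carbon. In this assay, 3,4-difluorophenyl in place of 4-aminophenyl gives a 9.2-fold higher number from compound 1 to compound 4 (0.96 log units; beyond the scatter), so the result at this position depends on which ring sits there, and a ring carrying no hydrogen-bond donor or acceptor still yields a number. Compound 3, with another ring at this place, stays at a limit and gives no number: the limit of > 100000 nM in this assay, at which 1 of the 4 values shown sits.

This single exchange removes the amino group and adds two fluorines at once, so it remains open which of these accounts for the step. From the compounds shown here alone, an unsubstituted phenyl ring, a monofluorophenyl ring or a hydroxyphenyl ring on the carbonyl carbon of the core of compound 1 would help to separate the two, and the effect of such rings is still unknown.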